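The source may report more compounds than this note shows. Statements on the series, on what has been measured and on what is new or still open speak of the compounds shown alone.

Compound 1 `O=[N+]([O-])c1cc(C(F)(F)F)cc([N+](=O)[O-])c1Oc1ccc(Br)cc1/C=N\OCc1ccccc1F`: 1120 nM
Compound 2 `O=[N+]([O-])c1cc(C(F)(F)F)cc([N+](=O)[O-])c1Oc1c(Br)cc(Br)cc1/C=N\OCc1ccccc1F`: 880 nM
Compound 3 `O=[N+]([O-])c1cc(C(F)(F)F)cc([N+](=O)[O-])c1Oc1c(Br)cc(Br)cc1/C=N/OCc1ccc(Cl)cc1Cl`: not yet measured

In a functional assay on MCF7 cells (Homo sapiens) for antiproliferative activity, read by MTT assay, with a stated time of 48 h (on this read-out lower numbers stand for stronger inhibition and higher numbers for weaker inhibition), compound 2 gives 880 nM and compound 1 gives 1120 nM, so the two stand within the scatter of each other. Compound 3 differs from compound 2 as follows: a group of 12 heavy atoms (8 carbon, 1 nitrogen, 1 oxygen, 2 chlorine; one six-membered aromatic ring of carbon only) in place of a group of 11 heavy atoms (8 carbon, 1 nitrogen, 1 oxygen, 1 fluorine; one six-membered aromatic ring of carbon only), on an aromatic carbon. Going by the values given here, the only measured step, a 1.3-fold lower number from compound 1 to compound 2 (0.10 log units; within the scatter), is bromo in place of hydrogen on an aromatic carbon. It lies within the scatter and leaves this group untouched. Among the compounds with values here, no measured compound carries the entering group, so the evidence is thin, and no step beyond the scatter is expected in this assay. The expected change is a 1.1-fold lower number from compound 2 to compound 3 (0.04 log units; within the scatter). For compound 3 the estimated value is 800 nM, with an expected range of 300 nM to 2200 nM.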

Compound 3, half-maximal inhibitory concentration: 2090 nM
The estimate for compound 3 lay 2.6-fold (0.42 log units) below the measured number; measured number inside the range.
By their numbers in this assay, from the lowest: compounds 2, 1 and 3 (each within the scatter of the next, the first and the last beyond it).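

In this assay, going by these compounds alone, the group with 2 chlorine in place of the group with 1 fluorine, on an aromatic carbon, gives a 2.4-fold higher number from compound 2 to compound 3 (0.38 log units; beyond the scatter), the first step beyond the scatter. This position therefore responds to substitution, whereas the bromo step left the number within the scatter. Nothing measured here offers an explanation for this step.

The entry of chlorine and the loss of fluorine come together, so their separate contributions cannot be told apart. As far as these compounds go, how an amine or a carboxylic acid on this ring would stand remains open.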